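This account rests on a few compounds, and the source may have more. Where it says the series, first, only, none or still open, it means among the compounds named here.

Working notes on the series. Compound 1 `C/C(=C\c1cc(-c2cccnc2)co1)C(N)=O` in a functional assay on BGC-823 cells (Homo sapiens) for cytotoxicity, read by CCK-8 assay, with a stated time of 24 h (a lower number here means a stronger inhibitor, a higher number a weaker inhibitor), gives > 50000 nM, a limit of the assay. Compound 2 `C/C(=C\c1cc(-c2ccc(C)nc2)co1)C(N)=O` in this assay gives > 50000 nM, also a limit. Between them stands (methyl in place of hydrogen on an aromatic carbon), and the step that the two limits leave unreadable from compound 1 to compound 2 cannot be sized, because of the limit of > 50000 nM in this assay, at which 3 of the 3 values shown sit. Compound 3 `C/C(=C\c1cc(-c2ccccc2)cs1)C(N)=O` in this assay gives > 50000 nM, again a limit. The difference between the cores of compound 1 and compound 3 is not broken down here. Compound 4 `C/C(=C\c1cc(-c2ccccc2C)cs1)C(N)=O` carries methyl in place of hydrogen on an aromatic carbon; against compound 2 the place differs, there on a six-membered aromatic ring with 1 nitrogen, next to the ring nitrogen, para to a large group, here on a six-membered aromatic ring of carbon only, ortho to a large group, so the same kind of change, not the same. From compound 3 the expected step is a step that the limit leaves unreadable from compound 3 to compound 4, resting on compound 3 at > 50000 nM and on the unreadable a step that the two limits leave unreadable from compound 1 to compound 2. Compound 4 is expected at 60000 nM, between 20000 nM and 200000 nM.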

Compound 4, half-maximal inhibitory concentration: > 50000 nM
Compound 4 gave a limit, no number (the forecaster's own chance of this, stated with the estimate: 80%); the middle value does not contradict the limit.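

No new step can be read between compound 3 and compound 4, because both sit at the same limit: the limit of > 50000 nM in this assay, at which 4 of the 4 values shown sit.

The compounds shown leave open whether methyl in place of hydrogen on an aromatic carbon changes the result in this assay at all.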